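A few compounds are considered here, and "the series" means these few. Any claim that something is new, unique, unknown or untested is made for them only; others in the source may bear on it.

Of the compounds shown here, three sharing one core have been tested in a physicochemical assay for solubility, at pH 7.4; a lower number here means a less soluble compound, a higher number a more soluble compound. Compound 1 `OCCNc1nc(NCc2ccco2)c2ccccc2n1` gives <= 20000 nM, which is a limit of the assay rather than a number. Compound 2 `CCCCNc1nc(NCCCC)c2ccccc2n1` gives <= 10000 nM, also a limit. Compound 3 `CNc1nc(NCc2ccccc2)nc2ccccc12` gives <= 10000 nM, again a limit. So compound 3 stands at a limit, as do the other two values, and no step between measured compounds can be read from them; the evidence is only the limit of <= 10000 nM in this assay, at which 2 of the 3 values shown sit, and (the limit of <= 20000 nM in this assay, at which 1 of the 3 values shown sits). Compound 4 `c1ccc(CNc2nc(Nc3ccccc3)c3ccccc3n2)cc1` differs from compound 3 by phenyl in place of methyl on a nitrogen on an aromatic ring. In this assay the expected step is a step that the limit leaves unreadable from compound 3 to compound 4, downward and beyond the usual scatter. Compound 4 is estimated at 3000 nM, between 500 nM and 10000 nM, and would probably again be reported only as a limit.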

Compound 4, solubility: <= 5000 nM
Compound 4: no number, only a limit; the forecaster's own chance of this, stated with the estimate: 80%; the middle value does not contradict the limit.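

In this assay compound 4 gives <= 5000 nM, which is a limit. Going by these compounds alone, compound 3 also stands at a limit, so no step between compound 3 and compound 4 can be read. Going by these compounds, the actual solubility of all four compounds remains open.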